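Removing the methoxy of compound 2: what to expect

The source may report more compounds than this note shows. Statements on the series, on what has been measured and on what is new or still open speak of the compounds shown alone.

The measured compounds and their values in a functional assay on L1210 cells (Mus musculus) for antiproliferative activity, read by MTT assay, with a stated time of 72 h; on this read-out lower numbers stand for stronger inhibition and higher numbers for weaker inhibition:
compound 1 `COc1ccc(C2=NN(C(C)=O)C(c3cccc([N+](=O)[O-])c3)O2)cc1` — 47000 nM
compound 2 `COc1ccc(C2=NN(C(C)=O)C(c3cccc(OC)c3)O2)cc1` — 41000 nM
compound 3 `COc1ccc(C2=NN(C(C)=O)C(c3cc(OC)ccc3OC)O2)cc1` — 500 nM

Compound 2 stands second highest of the three numbers. Its nearest neighbour is compound 1, whose number is higher only within the scatter, and the step of a 1.1-fold lower number from compound 1 to compound 2 (0.06 log units; within the scatter) shows that exchanging the substituent at this position changes little. Its furthest neighbour is compound 3, reached by the step of an 82-fold lower number from compound 2 to compound 3 (1.91 log units; beyond the scatter), a large step that comes from a second methoxy added elsewhere on the ring.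

Compound 4 `COc1ccc(C2=NN(C(C)=O)C(c3ccccc3)O2)cc1` differs from compound 2 by hydrogen in place of methoxy on an aromatic carbon. The step from compound 1 to compound 2 bears most directly on this change, since it also alters the group at this position and stayed within the scatter. The step from compound 2 to compound 3 concerns a different position and does not apply. The account therefore expects no step beyond the scatter in this assay for compound 4, and estimates 50000 nM (range 20000 nM to 125000 nM), an expected change of a 1.2-fold higher number from compound 2 to compound 4 (0.09 log units; within the scatter).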

Compound 4, half-maximal inhibitory concentration: > 100000 nM
Compound 4: only a limit was reported (the forecaster's own chance of this, stated with the estimate: 15%); at least 2.0-fold (0.30 log units) between middle value and limit.
By their numbers in this assay, from the lowest: compound 3; then compounds 2 and 1 (each within the scatter of the next). At a limit, above all of these: compound 4.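

In this assay compound 4 is reported only as a limit, > 100000 nM. The position meta to a large group is therefore not indifferent to its substituent: with hydrogen there, the number moves up by an at least 2.4-fold higher number from compound 2 to compound 4 (0.38 log units; beyond the scatter), and likewise by an at least 2.1-fold higher number from compound 1 to compound 4 (0.32 log units; beyond the scatter). Methoxy and nitro, within the scatter of each other, thus both stand apart from hydrogen, which the exchange of nitro for methoxy alone could not show, and both steps are minimum sizes whose true extent stays unknown: the limit of > 100000 nM in this assay, at which 1 of the 4 values shown sits.

Open, on these data alone, is whether other groups at this position, such as an amine, a hydroxyl or a carboxylic acid, would sit with methoxy and nitro or with hydrogen. Also open, as far as these compounds go, is how large the gap to hydrogen really is.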